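The compounds below may be only part of what the source reports. "The series", "measured", "known", "first", "only" and "open" are said of these compounds alone.

Working notes on the series.

Compound 1 `CCCCCCCCCCCCS(=O)(=O)NC(=O)Nc1c(C(C)C)cccc1C(C)C` and compound 2 `CCCCCCCCCCCCCCS(=O)(=O)NC(=O)Nc1c(C(C)C)cccc1C(C)C` share one core and differ only in the chain on the sulfonyl side. In an assay on microsomes from intestine for inhibition of acyl-CoA:cholesterol acyltransferase (Oryctolagus cuniculus) (a higher number here means a weaker inhibitor, a lower number a stronger inhibitor), compound 1 gives 2330 nM and compound 2 gives 830 nM. The step of a 2.8-fold lower number from compound 1 to compound 2 (0.45 log units; beyond the scatter) is the only one available, and it goes with ethyl in place of hydrogen on a saturated chain carbon, ten or more bonds along the chain from a sulfonyl sulfur. Among the compounds with values here, compound 2 therefore stands lowest of the two numbers in this assay, with compound 1 as its only neighbour.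

Compound 3 `CCCCCCCCCCCCCC(c1ccccc1)S(=O)(=O)NC(=O)Nc1c(C(C)C)cccc1C(C)C` keeps the chain of compound 2 and changes (phenyl in place of hydrogen on a saturated chain carbon bound to a saturated chain carbon and a sulfonyl sulfur). Within the data shown here, no measured step touches this place on the chain; the step from compound 1 to compound 2 concerns a distant chain carbon and cannot be carried over. Absent a bearing step, the expectation for compound 3 is a step of a 1.2-fold lower number from compound 2 to compound 3 (0.07 log units; within the scatter), within or near the scatter, in this assay. Compound 3 is thus estimated at 700 nM, expected to lie between 200 nM and 2500 nM.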

Compound 3, half-maximal inhibitory concentration: 2000 nM
For compound 3 the middle estimate is 2.9-fold (0.46 log units) below the measured one; the range from low to high includes it.
By their numbers in this assay, from the lowest: compound 2; then compounds 3 and 1 (each within the scatter of the next).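

Phenyl in place of hydrogen on a saturated chain carbon bound to a saturated chain carbon and a sulfonyl sulfur gives a 2.4-fold higher number from compound 2 to compound 3 (0.38 log units; beyond the scatter) in this assay and so shows that a change at this carbon can move the number beyond the scatter, here toward weaker inhibition. The step is only modest, and compound 3 at 2000 nM remains measurable in this assay with 6 more heavy atoms on this carbon. Nothing measured here bears on why phenyl has this effect.

As far as these compounds go, whether the weakening belongs to phenyl itself or would follow any group on this carbon stays open, and a methyl, a benzyl or a carboxylic acid there would separate the two. Also open, from the compounds shown here alone, is whether a longer chain would keep lowering the number, and whether it would do so with phenyl present.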